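The compounds below may be only part of what the source reports. "The series", "measured", "known", "first", "only" and "open" are said of these compounds alone.

In a functional assay on BaF3 cells (Mus musculus) for antiproliferative activity, read by CCK-8 assay and cell counting, with a stated time of 76 h (on this read-out higher numbers stand for weaker inhibition and lower numbers for stronger inhibition), three compounds with a shared core have been measured. Compound 1 `COc1cc2nccc(Oc3ccc(Nc4nn(C)cc4C(=O)NC4CCCCC4)cc3)c2cc1C(N)=O` gives 4800 nM, and compound 3 `COc1cc2nccc(Oc3ccc(Nc4nn(C)cc4C(=O)Nc4ccccc4F)cc3)c2cc1C(N)=O` gives 1710 nM. Compound 2 `COc1cc2nccc(Oc3ccc(Nc4nn(C)cc4C(=O)NCC4CCCO4)cc3)c2cc1C(N)=O` gives > 10000 nM, which is a limit of the assay and not a number. The steps of an at least 2.0-fold higher number from compound 1 to compound 2 (0.31 log units; beyond the scatter) and a 2.8-fold lower number from compound 1 to compound 3 (0.45 log units; beyond the scatter) show how the first and third compounds differ, and compound 2 stands at the weak end of the three.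

Compound 4 `COc1cc2nccc(Oc3ccc(Nc4nn(C)cc4C(=O)NOCc4ccccc4)cc3)c2cc1C(N)=O` carries benzyloxy in place of (oxolan-2-yl)methyl on an amide-type nitrogen. The nearest measured change, to the ring-bearing 2-fluorophenyl, gave an at least 5.8-fold lower number from compound 2 to compound 3 (0.76 log units; beyond the scatter), so a similar move towards stronger inhibition is expected. In this assay the expected step is an at least 3.3-fold lower number from compound 2 to compound 4 (0.52 log units; beyond the scatter). For compound 4 the estimated value is 3000 nM, with an expected range from 800 nM to 10000 nM.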

Compound 4, half-maximal inhibitory concentration: > 10000 nM
Compound 4: a limit, no number; the forecaster's own chance of this, stated with the estimate: 20%; middle value at least 3.3-fold (0.52 log units) from the limit.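

Compound 4 gives > 10000 nM, which is a limit of the assay and not a number. Benzyloxy in place of 2-fluorophenyl gives an at least 5.8-fold higher number from compound 3 to compound 4 (0.76 log units; beyond the scatter), and benzyloxy in place of cyclohexyl gives an at least 2.0-fold higher number from compound 1 to compound 4 (0.31 log units; beyond the scatter), so a six-membered aromatic ring on this amide-type nitrogen does not by itself bring the stronger inhibition seen with compound 3. The step between compound 2 and compound 4 cannot be read, because both values sit at the same limit: the limit of > 10000 nM in this assay, at which 2 of the 4 values shown sit.

As far as these compounds go, whether plain phenyl, without the fluorine, would match compound 3 remains open. So does whether an amine or a carboxylic acid on the same nitrogen would give a measurable value.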